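Replacing Methyl with Phenylsulfonyl on a Ring Nitrogen

This account rests on a few compounds, and the source may have more. Where it says the series, first, only, none or still open, it means among the compounds named here.

In a functional assay on SF-268 cells (Homo sapiens) for cytotoxicity, read by MTT assay, with a stated time of 3 days (a higher number here means a weaker inhibitor, a lower number a stronger inhibitor), compound 1 `CNc1nc(SCc2nc3ccccc3[nH]2)nc(-c2ccccc2)c1C#N` gives 3.2 nM and compound 2 `N#Cc1c(-c2ccccc2)nc(SCc2nc3ccccc3[nH]2)nc1N1CCNCC1` gives 20000 nM, while compound 3 `CN1CCN(c2nc(SCc3nc4ccccc4[nH]3)nc(-c3ccccc3)c2C#N)CC1` gives 6.9 nM as the second highest of the three numbers. Compound 4 `N#Cc1c(-c2ccccc2)nc(SCc2nc3ccccc3[nH]2)nc1N1CCN(S(=O)(=O)c2ccccc2)CC1` differs from compound 3 by phenylsulfonyl in place of methyl on an amine nitrogen in a ring with phenylsulfonyl in place of methyl on an amine nitrogen in a ring. Two large steps show how much this nitrogen can matter: a 6300-fold higher number from compound 1 to compound 2 (3.80 log units; beyond the scatter) for piperazin-1-yl in place of methylamino and a 2900-fold lower number from compound 2 to compound 3 (3.46 log units; beyond the scatter) for methyl in place of hydrogen. The step of a 2.2-fold higher number from compound 1 to compound 3 (0.33 log units; beyond the scatter) is only modest. For the measured compounds named here, no measured compound carries phenylsulfonyl, so a moderately higher number is expected, with wide uncertainty. The estimate amounts to an 8.7-fold higher number from compound 3 to compound 4 (0.94 log units; beyond the scatter) as the expected change. Compound 4 is estimated at 60 nM with an expected range from 4 nM to 2000 nM until its measurement is known.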

Compound 4, half-maximal inhibitory concentration: 2.87 nM
Compound 4: the middle estimate sits 21-fold (1.32 log units) above what was measured; measured number outside the range, below it.
By their numbers in this assay, from the lowest: compounds 4 and 1 (each within the scatter of the next); then compound 3; then compound 2.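

In this assay, the amine nitrogen in a ring accepts far more than methyl: phenylsulfonyl, with its six-membered aromatic ring, gives a 2.4-fold lower number from compound 3 to compound 4 (0.38 log units; beyond the scatter). Measured against hydrogen on that nitrogen, the same group gives a 7000-fold lower number from compound 2 to compound 4 (3.84 log units; beyond the scatter), so the low numbers are not confined to methyl among the groups shown. No measured evidence here accounts for either step. Going by these compounds, whether an acetyl group, a benzyl group or a longer alkyl chain on this nitrogen would also give a low number remains open.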